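Oxolane for hydroxymethyl on the chain at the ring nitrogen

This account rests on a few compounds, and the source may have more. Where it says the series, first, only, none or still open, it means among the compounds named here.

Compound 1: `N=c1c2c(-c3ccccc3)c(-c3ccccc3)n(CC3CC3)c2ncn1C1CCOCC1` — 1.13 h
Compound 2: `COc1ccc(-c2c(-c3ccc(OC)cc3)n(Cc3ccccc3)c3ncn(CCO)c(=N)c23)cc1` — 1.22 h

The two measured compounds were run in an ADME assay on microsomes from liver (Mus musculus, strain CD1) for metabolic stability, read by LC-MS, using NADPH, with a stated time of 60 min; a lower number here means that the compound disappears faster, a higher number that the compound lasts longer. Compound 1, with the structure `N=c1c2c(-c3ccccc3)c(-c3ccccc3)n(CC3CC3)c2ncn1C1CCOCC1`, gives a half-life of 1.13 h. Compound 2, with the structure `COc1ccc(-c2c(-c3ccc(OC)cc3)n(Cc3ccccc3)c3ncn(CCO)c(=N)c23)cc1`, gives 1.22 h. Compound 2 lies within the scatter of compound 1, so the two half-lives cannot be told apart.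

Compound 3, with the structure `COc1ccc(-c2c(-c3ccc(OC)cc3)n(Cc3ccccc3)c3ncn(CC4CCOC4)c(=N)c23)cc1`, has not yet been measured. It differs from compound 2 in one place: oxolan-3-yl in place of hydroxymethyl on a saturated chain carbon bound to an aromatic nitrogen. No step between measured compounds is shown, so nothing in the data sets the size of this change. The author expects a step of a 1.0-fold lower number from compound 2 to compound 3 (0.01 log units; within the scatter) in this assay, that is, none beyond the scatter. Compound 3 is therefore estimated at 1.2 h, within a range from 0.6 h to 2.4 h.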

Compound 3, half-life: 0.275 h
Compound 3: middle estimate off by 4.4-fold (0.64 log units), on the high side, and the stated range ends above it.
By their numbers in this assay, from the lowest: compound 3; then compounds 1 and 2 (each within the scatter of the next).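

The chain on the ring nitrogen proved not to be a neutral place for change: in this assay, oxolan-3-yl in place of hydroxymethyl gives a 4.4-fold lower number from compound 2 to compound 3 (0.65 log units; beyond the scatter), a step that compound 1 and compound 2 alone could not reveal. The change removes the hydrogen-bond donor and adds a five-membered non-aromatic ring, and this single step does not separate these two differences. Nothing available bears on why the half-life shortens.

On these data alone, it remains open whether methoxymethyl or an open butyl chain at this place would stand with compound 2 or with compound 3 in this assay. Also open, as far as these compounds go, is whether the step would be the same on a core carrying other substituents, as it rests on this one pair.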